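This account rests on a few compounds, and the source may have more. Where it says the series, first, only, none or still open, it means among the compounds named here.

In a functional assay on MDA-MB-231 cells (Homo sapiens) for antiproliferative activity, read by MTT assay, with a stated time of 72 h (on this read-out lower numbers stand for stronger inhibition and higher numbers for weaker inhibition), compound 1 `CCN(CC)C(=S)SSCCO` gives 10000 nM and compound 2 `CCN(CC)C(=S)SSC(C)C` gives 960 nM as the lower of the two numbers. Compound 3 `CCC(C)SSC(=S)N(CC)CC` carries methyl in place of hydrogen on a saturated chain carbon, two bonds along the chain from a sulfur in the form of methyl in place of hydrogen on a saturated chain carbon, two bonds along the chain from a sulfur, turning isopropyl into sec-butyl. Among the measured compounds shown here, the one measured step of a 10-fold lower number from compound 1 to compound 2 (1.02 log units; beyond the scatter) is large but is a different change, isopropyl in place of 2-hydroxyethyl on a sulfur, so it gives no direct size for this one. Only a small shift toward a lower number, or none beyond the scatter, is expected in this assay here. The expected change is a 1.2-fold lower number from compound 2 to compound 3 (0.08 log units; within the scatter) for this pair. Expected for compound 3 is 800 nM as the estimate, with 300 nM to 2500 nM as its range.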

Compound 3, half-maximal inhibitory concentration: 6000 nM
Beside the measured number, compound 3's estimate is 7.5-fold (0.88 log units) below it, and the stated range ends below it.
By their numbers in this assay, from the lowest: compound 2; then compounds 3 and 1 (each within the scatter of the next).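

In this assay, methyl in place of hydrogen on a saturated chain carbon, two bonds along the chain from a sulfur, turns isopropyl into sec-butyl and gives a 6.3-fold higher number from compound 2 to compound 3 (0.80 log units; beyond the scatter) and so this position is sensitive to a small added group. Sec-butyl in place of 2-hydroxyethyl on a sulfur gives a 1.7-fold lower number from compound 1 to compound 3 (0.22 log units; within the scatter) and so the advantage of isopropyl is not kept by sec-butyl. Open, on these data alone, is whether tert-butyl, cyclopropyl or a longer chain on the sulfur would follow isopropyl or sec-butyl. Nothing at hand gives a reason for either step.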